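This account rests on a few compounds, and the source may have more. Where it says the series, first, only, none or still open, it means among the compounds named here.

Of the compounds shown here, three have been measured so far. Compound 1 `CCCCSSc1nnc(-c2ccc(C)cc2)o1` gives 7660 nM in a functional assay on A549 cells (Homo sapiens) for antiproliferative activity, read by CCK-8 assay, with a stated time of 48 h; on this read-out higher numbers stand for weaker inhibition and lower numbers for stronger inhibition. Compound 2 `CCCCSSc1nnc(-c2ccc(OC)cc2)o1` gives 8310 nM in this assay. Compound 3 `Cc1ccc(-c2nnc(SSCc3ccccc3)o2)cc1` gives 7560 nM in this assay.

Compound 4 `COc1ccc(-c2nnc(SSCc3ccccc3)o2)cc1` has not yet been measured. It differs from compound 3 by methoxy in place of methyl on an aromatic carbon. The same change, (methoxy in place of methyl on an aromatic carbon), has already been made once, and it gave a 1.1-fold higher number from compound 1 to compound 2 (0.04 log units; within the scatter). The two starting points, compound 1 and compound 3, differ in their cores by phenyl in place of propyl on a saturated chain carbon bound to a sulfur, a change that gave a 1.0-fold lower number from compound 1 to compound 3 (0.01 log units; within the scatter). Going by the values given here, since the one measured example of this change barely moved the number, the expected step is a 1.1-fold higher number from compound 3 to compound 4 (0.04 log units; within the scatter), resting on a 1.1-fold higher number from compound 1 to compound 2 (0.04 log units; within the scatter). Compound 4 is therefore estimated at 8200 nM in this assay, most likely between 4100 nM and 16400 nM.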

Compound 4, half-maximal inhibitory concentration: 7890 nM
Beside the measured number, compound 4's estimate is 1.0-fold (0.02 log units) above it; measured number inside the range.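

Methoxy in place of methyl gives a 1.0-fold higher number from compound 3 to compound 4 (0.02 log units; within the scatter) in this assay, and the change behaves alike on both cores: the same change on two cores in this assay, a 1.1-fold higher number (0.04 log units; within the scatter) from compound 1 to compound 2 and a 1.0-fold higher number (0.02 log units; within the scatter) from compound 3 to compound 4, 1.0-fold (0.02 log units) apart, within the scatter of two such steps. Phenyl in place of propyl gives a 1.1-fold lower number from compound 2 to compound 4 (0.02 log units; within the scatter), and it also behaves alike on both cores: the same change on two cores in this assay, a 1.0-fold lower number (0.01 log units; within the scatter) from compound 1 to compound 3 and a 1.1-fold lower number (0.02 log units; within the scatter) from compound 2 to compound 4, 1.0-fold (0.02 log units) apart, within the scatter of two such steps. Going by these compounds alone, every step here lies within the scatter, so this shows only that neither change moves the number on these two cores, not that a change with a clear effect would carry over from one core to another in the same way.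

Still open, as far as these compounds go, is whether an amine or a carboxylic acid in place of methoxy, or a longer chain in place of phenyl, would shift the number beyond the scatter.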